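Swapping a Furan for a 2-Hydroxyphenyl Group

The source may report more compounds than this note shows. Statements on the series, on what has been measured and on what is new or still open speak of the compounds shown alone.

In a functional assay on SMMC-7721 cells (Homo sapiens) for antiproliferative activity, read by MTT assay, with a stated time of 72 h (on this read-out higher numbers stand for weaker inhibition and lower numbers for stronger inhibition), compound 1 `C/C(=N\NC(=O)c1cccc(S(=O)(=O)N2CCOCC2)c1)c1cc(Br)ccc1O` gives 2410 nM as a measured number. Compound 2 `O=C(N/N=C/c1ccco1)c1cccc(S(=O)(=O)N2CCOCC2)c1` reads > 100000 nM and that is a limit of the assay, not a number. Compound 3 `O=C(N/N=C/c1ccccc1O)c1cccc(S(=O)(=O)N2CCOCC2)c1` differs from compound 2 by one swap 2-hydroxyphenyl in place of furan-2-yl on a carbon with a double bond to nitrogen with 2-hydroxyphenyl in place of furan-2-yl on a carbon with a double bond to nitrogen. Compound 1 also carries a hydroxy group on an aromatic ring and reaches 2410 nM in this assay so a large move toward stronger inhibition is expected. The expected change is an at least 12-fold lower number from compound 2 to compound 3 (1.09 log units; beyond the scatter) in size. Compound 3 is estimated at 8000 nM with an expected range of 1500 nM to 45000 nM for this estimate.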

Compound 3, half-maximal inhibitory concentration: 12100 nM
Estimate against measurement, compound 3: 1.5-fold (0.18 log units) below, within the range that was stated.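

Placing 2-hydroxyphenyl instead of furan-2-yl on the carbon with a double bond to nitrogen gives the first one-place comparison at this position in this assay, and the swap brings an at least 8.2-fold lower number from compound 2 to compound 3 (0.91 log units; beyond the scatter). So this position does respond to the group it carries. The true size of the step stays unknown because compound 2 reads only as a limit of the assay, not a number: the limit of > 100000 nM in this assay, at which 1 of the 3 values shown sits.

Going by these compounds, whether the hydroxy group or the six-membered aromatic ring carries the change remains open. So does the outcome with an amine or a methoxy group in place of that hydroxy group.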